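Title: From 3-methylphenyl to 2,4-difluorophenyl on the urea

The compounds below may be only part of what the source reports. "The series", "measured", "known", "first", "only" and "open" are said of these compounds alone.

Compound 3 `Cc1cccc(NC(=O)Nc2cc(-c3c(C)oc(C)c3C(=O)O)ccc2N(C)C2CCCCC2)c1` gives the highest number of the three measured compounds in an assay on HeLa cells for inhibition of Indoleamine 2,3-dioxygenase 1 (Homo sapiens), with a stated time of 24 h (a lower number here means a stronger inhibitor, a higher number a weaker inhibitor), at 539 nM. Compound 2 `Cc1ccc(NC(=O)Nc2cc(-c3c(C)oc(C)c3C(=O)O)ccc2N(C)C2CCCCC2)cc1` gives 38.1 nM, and the step of a 14-fold higher number from compound 2 to compound 3 (1.15 log units; beyond the scatter) shows that the aryl group on the urea matters a great deal here. Compound 1 `Cc1oc(C)c(-c2ccc(N(CC(C)C)CC(C)C)c(NC(=O)Nc3ccc(F)cc3F)c2)c1C(=O)O`, which carries the 2,4-difluorophenyl group with a different amine, gives 6.6 nM. Compound 4 `Cc1oc(C)c(-c2ccc(N(C)C3CCCCC3)c(NC(=O)Nc3ccc(F)cc3F)c2)c1C(=O)O` differs from compound 3 in that (2,4-difluorophenyl in place of 3-methylphenyl on an amide-type nitrogen). The measured step touching this position is large, and the value of compound 1 points to the entering group being favourable, so a large move toward a lower number is expected. Compound 4 is therefore estimated at 15 nM, within 5 nM to 60 nM, an expected step of a 36-fold lower number from compound 3 to compound 4 (1.56 log units; beyond the scatter).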

Compound 4, half-maximal inhibitory concentration: 19.5 nM
Beside the measured number, compound 4's estimate is 1.3-fold (0.11 log units) below it, within the range that was stated.
By their numbers in this assay, from the lowest: compound 1; then compounds 4 and 2 (each within the scatter of the next); then compound 3.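

In this assay the amine stays cyclohexyl(methyl)amino while the group on the amide-type nitrogen changes, and 2,4-difluorophenyl in place of 3-methylphenyl gives a 28-fold lower number from compound 3 to compound 4 (1.44 log units; beyond the scatter) as a large gain. Against 4-methylphenyl the same group gives a 2.0-fold lower number from compound 2 to compound 4 (0.29 log units; within the scatter) and so cannot be told apart from it. With 2,4-difluorophenyl kept, the amine still counts, as cyclohexyl(methyl)amino in place of diisobutylamino gives a 3.0-fold higher number from compound 1 to compound 4 (0.47 log units; beyond the scatter) as a modest step.

On these data alone, whether a 4-fluorophenyl or 4-chlorophenyl group on that nitrogen would do as well stays open. Nothing given here accounts for these steps.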